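Fluoro for nitro: expected cytotoxicity of compound 4

The source may report more compounds than this note shows. Statements on the series, on what has been measured and on what is new or still open speak of the compounds shown alone.

In a toxicity assay on HepG2 2.2.15 cells (Homo sapiens) for cytotoxicity, read by CCK-8 assay, with a stated time of 8 days (on this read-out lower numbers stand for higher toxicity in this test and higher numbers for lower toxicity in this test), compound 3 `CCOC(=O)c1cn(-c2ccccc2[N+](=O)[O-])nc1CC(C)C` gives 4850 nM, the lowest of the two numbers recorded in the set. Compound 2 `CC(C)Cc1nn(-c2cccc(F)c2)cc1C(=O)NCc1ccccc1` gives 85900 nM, a gap beyond the usual scatter. Compound 1 `CCOC(=O)c1cn(-c2nccs2)nc1CC(C)C` reaches only > 100000 nM, which is a limit of this assay and not a number (the limit of > 100000 nM in this assay, at which 1 of the 3 values shown sits). Compound 4 `CCOC(=O)c1cn(-c2ccccc2F)nc1CC(C)C` differs from compound 3 by fluoro in place of nitro on an aromatic carbon. Among the compounds with values here, no measured pair isolates this change. An upward step an 8.2-fold higher number from compound 3 to compound 4 (0.92 log units; beyond the scatter) in this assay is nevertheless expected, and beyond the scatter. The expectation rests on compound 2, which gives 85900 nM without a nitro group. Compound 4 is estimated at 40000 nM, in a range from 8000 nM to 120000 nM.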

Compound 4, half-maximal cytotoxic concentration: > 100000 nM
Compound 4 was reported as a limit; the forecaster's own chance of this, stated with the estimate: 30%; middle value at least 2.5-fold (0.39 log units) away from the limit.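

In this assay, fluoro in place of nitro on an aromatic carbon, ortho to a large group, gives an at least 20-fold higher number from compound 3 to compound 4 (1.31 log units; beyond the scatter), so in this pair the low number goes with the nitro group and does not survive its replacement by fluoro. The value of compound 4 is a limit and not a number: the limit of > 100000 nM in this assay, at which 2 of the 4 values shown sit. The step between the two limit compounds cannot be read. Open, as far as these compounds go, is whether an amine or a methoxy group at this position gives a number below the limit, or stays there like fluoro.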